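The source may hold more compounds than are shown below. What is called first, only, known or untested is meant among the compounds shown, and "the series" means these compounds.

Of the compounds shown here, three sharing one core have been measured. Compound 1 `COc1cc(OC)c(C(=O)/C=C/c2ccc(Cl)cc2)c(OC)c1` gives 7600 nM in a functional assay on HaCaT cells (Homo sapiens) for cytotoxicity, with a stated time of 48 h; a higher number here means a weaker inhibitor, a lower number a stronger inhibitor. Compound 2 `COc1cccc(/C=C/C(=O)c2c(O)cc(OC)cc2OC)c1` gives 10400 nM, and compound 3 `COc1cc(OC)c(C(=O)/C=C/c2ccc([N+](=O)[O-])cc2)c(OC)c1` gives 2800 nM. Compound 1 thus stands second highest of the three: its value and that of compound 2 lie within the scatter of each other, while the only single-change step shown, a 2.7-fold lower number from compound 1 to compound 3 (0.43 log units; beyond the scatter), goes beyond the scatter. Compound 4 `COc1cc(OC)c(C(=O)/C=C/c2ccc(F)cc2)c(OC)c1` has not yet been measured; it differs from compound 1 by fluoro in place of chloro on an aromatic carbon. Going by the values given here, no measured step exchanges one halogen for another, so the nitro step is only a loose guide. Compound 4 is therefore expected to move by a 1.1-fold higher number from compound 1 to compound 4 (0.05 log units; within the scatter), within the scatter. The estimated value of compound 4 in this assay is 8500 nM, with a range from 3500 nM to 20000 nM.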

Compound 4, half-maximal inhibitory concentration: 7600 nM
Compound 4: middle estimate off by 1.1-fold (0.05 log units), on the high side; the range from low to high includes it.
By their numbers in this assay, from the lowest: compound 3; then compounds 1, 4 and 2 (each within the scatter of the next).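

In this assay, fluoro in place of chloro gives no change at the digits printed from compound 1 to compound 4 (within the scatter) at this position on the ring, so the two halogens read alike here. Fluoro in place of nitro gives a 2.7-fold higher number from compound 3 to compound 4 (0.43 log units; beyond the scatter) and mirrors the earlier chloro-to-nitro step in size, which leaves compound 3 alone apart from the two halogen compounds. Nothing measured here offers a reason for this. Going by these compounds, what an amine or a carboxylic acid would give at this same place stays open, as does bromo. On these data alone, whether chloro and fluoro also read alike on another core stays open too.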